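The source may hold more compounds than are shown below. What is called first, only, known or untested is meant among the compounds shown, and "the series" means these compounds.

The series shares one core, seen in compound 1 `ONc1cccc(CNc2cc(Br)cc3[nH]ncc23)c1` and compound 2 `Brc1cc(NCc2ccco2)c2cn[nH]c2c1`. In an assay for inhibition of Tryptophan 2,3-dioxygenase (Homo sapiens), with a stated time of 1 h, tested at 10 uM (a higher number here means more inhibition at the concentration tested (going by the name of the read-out), a lower number less inhibition), compound 1 is recorded as "not active" (no number reported), with no number attached to it. In this assay compound 2 gives 64%, which is the only figure reported for the series; beside it stands just the entry for compound 1 without a single number. Compound 3 `Brc1cc(NCc2ccncc2)c2cn[nH]c2c1` has not yet been measured and differs from compound 2 in one place: pyridin-4-yl in place of furan-2-yl on a saturated chain carbon bound to a nitrogen on an aromatic ring. Going by the values given here, no step between two measured compounds has been reported, so nothing yet shows how the read-out responds to a change of this kind. The expected step in this assay, a number 16 percentage points lower from compound 2 to compound 3 (beyond the scatter), is a modest loss, estimated to lie near the edge of the usual scatter. Compound 3 is estimated at 48%, within a range of 15% to 75%.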

Compound 3, a percentage reported as inhibition, at one concentration (the size of the read-out at that concentration, not a potency): 55%
Beside the measured number, compound 3's estimate is 7 percentage points below it; low and high end bracket the measured number.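

In this assay, going by these compounds alone, pyridin-4-yl in place of furan-2-yl on a saturated chain carbon bound to a nitrogen on an aromatic ring gives a number 9 percentage points lower from compound 2 to compound 3 (within the scatter), the first step that can be read. At this position, then, a six-membered aromatic ring with 1 hetero atom and a five-membered aromatic ring with 1 hetero atom cannot be told apart by this read-out, so the change from one to the other carries no measurable penalty here. No measurement is available that would explain this result.

The compounds shown leave open whether this position also accepts a group without an aromatic ring, such as an amine or a carboxylic acid. They also leave open how a longer chain carrying the pyridin-4-yl group would read in this assay.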